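Cyclopropyl in place of phenethyl on the sulfur-linked chain

This account rests on a few compounds, and the source may have more. Where it says the series, first, only, none or still open, it means among the compounds named here.

Measured so far, in a functional assay on MGC-803 cells (Homo sapiens) for inhibition, read by MTT assay, with a stated time of 72 h; a higher number here means a weaker inhibitor, a lower number a stronger inhibitor:
- compound 1, `Cc1cc(Nc2cc(-c3ccccc3)[nH]n2)n2nc(SCCCc3ccccc3)nc2n1`, gives 6510 nM
- compound 2, `Cc1cc(Nc2cc(-c3ccccc3)[nH]n2)n2nc(SCc3ccccc3Br)nc2n1`, gives 3650 nM
- compound 3, `Cc1cc(Nc2cc(-c3ccccc3)[nH]n2)n2nc(SCc3ccc(Br)cc3)nc2n1`, gives 1110 nM

Compound 1 stands at the highest of the three numbers in this assay. Its nearest neighbour is compound 2, with a 1.8-fold lower number from compound 1 to compound 2 (0.25 log units; within the scatter); the furthest is compound 3, with a 5.9-fold lower number from compound 1 to compound 3 (0.77 log units; beyond the scatter). Between the two bromophenyl variants, a 3.3-fold lower number from compound 2 to compound 3 (0.52 log units; beyond the scatter).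

Compound 4, `Cc1cc(Nc2cc(-c3ccccc3)[nH]n2)n2nc(SCC3CC3)nc2n1`, differs from compound 1 as follows: cyclopropyl in place of phenethyl on a saturated chain carbon bound to a sulfur. Both measured steps leaving compound 1 swap the phenethyl for a bromophenyl group, so an aromatic ring stays in place while the chain is shortened; each of them lowered the number in this assay, the one by a margin within the scatter and the other by a modest margin. Among the measured compounds shown here, none of the measured steps removes the aromatic ring altogether, which is what the change to cyclopropyl does, so the bearing of those steps on compound 4 is indirect. The measured steps give no ground for expecting a lower number; a step near or somewhat above the number for compound 1 seems the more likely outcome, with wide uncertainty.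

Compound 4 is therefore expected to give 9000 nM in this assay, within a range of 3500 nM to 25000 nM, corresponding to an expected step of a 1.4-fold higher number from compound 1 to compound 4 (0.14 log units; within the scatter).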

Compound 4, half-maximal inhibitory concentration: 16100 nM
Compound 4: the middle estimate sits 1.8-fold (0.25 log units) below what was measured; the range from low to high includes it.
By their numbers in this assay, from the lowest: compound 3; then compounds 2 and 1 (each within the scatter of the next); then compound 4.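

In this assay compound 4 is the weakest of the four, and its steps to all the others lie beyond the scatter (a 2.5-fold higher number from compound 1 to compound 4 (0.39 log units; beyond the scatter)), (a 4.4-fold higher number from compound 2 to compound 4 (0.64 log units; beyond the scatter)) and (a 15-fold higher number from compound 3 to compound 4 (1.16 log units; beyond the scatter)). Among the compounds shown here, this is the first compound here that lacks a six-membered aromatic ring on the sulfur-linked chain, and across these four compounds, each group carrying such a ring gives a lower number than cyclopropyl, with no compound going against that pattern; the size of the gap depends on the group replaced, with the largest step coming from the 4-bromophenyl of compound 3 and the smallest from the phenethyl of compound 1. No measurement at hand accounts for these differences.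

The change to cyclopropyl removes the aromatic ring and also reduces the heavy-atom count, so the compounds shown do not separate the loss of the ring from the loss of size. An unsubstituted benzyl group would show what the bromine contributes in compound 3, while a cyclohexylmethyl group or an open n-hexyl chain would test whether a large saturated group can stand in for the aromatic ring at this place.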